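Cyclobutyl ether in place of thiazolyl ether on the chromane acid

The source may hold more compounds than are shown below. What is called first, only, known or untested is meant among the compounds shown, and "the series" means these compounds.

Measured so far:
compound 1, `COc1cc(OC(F)(F)F)cc(-c2ccc3c(c2)CC[C@H](CCc2nnn[nH]2)O3)c1F`: > 10000 nM
compound 2, `Cc1cnc(Oc2cc(Cl)c(F)c(-c3ccc4c(c3)CC[C@H](CCC(=O)O)O4)c2)s1`: > 10000 nM

In a functional assay on HEK293 cells for agonist activity at Free fatty acid receptor 1 (Homo sapiens), read by HTRF and inositol phosphate accumulation, with a stated time of 60 min (a lower number here means that less compound is needed, a higher number that more compound is needed for the effect), compound 1 gives only a limit, > 10000 nM. In this assay compound 2 also gives only a limit, > 10000 nM. Compound 2 therefore stands at the limit of > 10000 nM in this assay, at which 2 of the 2 values shown sit, and no number separates it from compound 1.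

Compound 3, `O=C(O)CC[C@H]1CCc2cc(-c3cc(OC4CCC4)cc(Cl)c3F)ccc2O1`, keeps the acid chain and the core of compound 2. The change is cyclobutyl in place of 5-methyl-1,3-thiazol-2-yl on an oxygen on an aromatic ring. No step between measured compounds covers this change, and both measured values are limits, so no direction is shown. The step of an at least 1.6-fold lower number from compound 2 to compound 3 (0.22 log units; that floor lies within the scatter) is expected as a modest move toward a lower number, uncertain and likely within the scatter of a limit. Compound 3 is expected to give 6000 nM, with a range from 800 nM to 30000 nM.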

Compound 3, half-maximal effective concentration: > 10000 nM
Compound 3 was reported as a limit; the forecaster's own chance of this, stated with the estimate: 55%; at least 1.6-fold (0.22 log units) between middle value and limit.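

In this assay, compound 2 and compound 3 both give only limits, so no step can be read for cyclobutyl in place of 5-methyl-1,3-thiazol-2-yl: the limit of > 10000 nM in this assay, at which 3 of the 3 values shown sit.

The compounds shown leave open whether the group on this oxygen changes the response in this assay at all, since none of them gives a number.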